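This account rests on a few compounds, and the source may have more. Where it says the series, first, only, none or still open, it means among the compounds named here.

Working notes on the series. The shared core carries an amine and an ether on the aromatic system, and the sugar-like ring differs at one position between the two measured compounds. Compound 1 `C[C@H]1O[C@@H](n2cnc3c(N)nc(OC4CCCC4)nc32)[C@H](O)[C@@H]1OCc1ccc(Cl)c(Cl)c1` has a dichlorobenzyl ether on that ring. In a physicochemical assay for lipophilicity, using the shake flask method, measured as octanol-water partition, at pH 7.4 (on this read-out higher numbers stand for higher lipophilicity and lower numbers for lower lipophilicity), compound 1 gives > 3.5, which is a limit of the assay rather than a number. Compound 2 `C[C@H]1O[C@@H](n2cnc3c(N)nc(OCC4CC45CC5)nc32)[C@H](O)[C@H]1Cl` carries a chlorine on the same ring instead, and in this assay compound 2 gives 3.7. Within the data shown here, this is the only number so far. The other entry, that of compound 1, is a limit (the limit of > 3.5 in this assay, at which 1 of the 2 values shown sits).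

Compound 3 `C[C@H]1O[C@@H](n2cnc3c(N)nc(OC4CCCC4)nc32)[C@H](O)[C@H]1Cl` differs from compound 2 in one place: a group of 5 heavy atoms (5 carbon; one five-membered non-aromatic ring of carbon only) in place of a group of 6 heavy atoms (6 carbon; 2 three-membered non-aromatic rings of carbon only), on an oxygen on an aromatic ring. Among the measured compounds shown here, no measured pair isolates this change. The expected step is a number 0.30 log units lower from compound 2 to compound 3 (within the scatter), a small shift downward that sits close to the usual scatter. Compound 3 is therefore estimated at 3.4, with a range from 2.9 to 3.9.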

Compound 3, distribution coefficient: 3.18
Compound 3: middle estimate off by 0.22 log units, on the high side, within the range that was stated.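

With the chlorine on the sugar-like ring held constant, replacing the group carrying two three-membered rings with cyclopentyl, on an oxygen on an aromatic ring, gives in this assay a number 0.52 log units lower from compound 2 to compound 3 (beyond the scatter). Among these compounds, this is the first sign that the group on this oxygen alone can move the read-out, which could not be seen while only one number stood. Compound 1 carries the same cyclopentyl but has a dichlorobenzyl ether on the sugar-like ring, and its entry is a limit and not a number, so no step to it can be read: the limit of > 3.5 in this assay, at which 1 of the 3 values shown sits.

Going by these compounds, whether this step carries over to other groups on the sugar-like ring remains open, since it rests on a single pair. Also open, on these data alone, is how an open chain such as n-pentyl, or a chain ending in an amine, would read on the same oxygen.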